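Three Measured Compounds and One Still Untested

The source may report more compounds than this note shows. Statements on the series, on what has been measured and on what is new or still open speak of the compounds shown alone.

Compound 1 `Cn1c(-c2cccc(F)c2)nnc1S(C)(=O)=O`, compound 2 `CSc1nnc(-c2ccc(C)cc2)n1C` and compound 3 `Cc1ccc(-c2nnc(S(C)(=O)=O)n2C)cc1` were examined in a functional assay on the whole organism for antagonist activity, with Mus musculus as the target, in the maximal electroshock model; on this read-out higher numbers stand for an effect only at larger amounts of compound and lower numbers for an effect already at smaller amounts. Compound 1 gave no number but only a limit of the assay, > 200 mg/kg. Compound 2 likewise reached only a limit, > 100 mg/kg. Compound 3 also stopped at a limit, > 200 mg/kg. Compound 3 and compound 2 differ in one place, (methylsulfanyl in place of methylsulfonyl on an aromatic carbon), yet the step that the two limits leave unreadable from compound 3 to compound 2 cannot be sized, because both ends are limits, the limit of > 100 mg/kg in this assay, at which 1 of the 3 values shown sits, and (the limit of > 200 mg/kg in this assay, at which 2 of the 3 values shown sit). Compound 4 `CSc1nnc(-c2cccc(F)c2)n1C` has not yet been tested in this assay. It differs from compound 1 by the same change, (methylsulfanyl in place of methylsulfonyl on an aromatic carbon), at the same place; the difference between the cores of compound 1 and compound 3 is not broken down here. The step that the limit leaves unreadable from compound 1 to compound 4 is expected to be small, an expectation that rests on compound 1 sitting at the limit of > 200 mg/kg in this assay, at which 2 of the 3 values shown sit, and on the step that the two limits leave unreadable from compound 3 to compound 2 giving no sign of any shift. Compound 4 is therefore estimated at 250 mg/kg, most probably once more only a limit rather than a number.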

Compound 4, dose for half-maximal effect: > 200 mg/kg
Compound 4 gave a limit, no number (the forecaster's own chance of this, stated with the estimate: 80%); the middle value is on the limit's open side.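

Compound 1 and compound 4 both end at a limit of the assay rather than a number in this assay, so the step between them cannot be read. The compounds shown leave open what dose any of them would need for an effect, and whether methylsulfanyl in place of methylsulfonyl changes that dose at all.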